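Aryl exchange on the shared core: compound 1 toward compound 4

The compounds below may be only part of what the source reports. "The series", "measured", "known", "first", "only" and "open" are said of these compounds alone.

Three members of the series have numbers in a functional assay on HeLa cells (Homo sapiens) for cytotoxicity, read by MTT assay, with a stated time of 48 h; on this read-out lower numbers stand for stronger inhibition and higher numbers for weaker inhibition. Compound 1, `COc1ccc(C(C2=C(O)C(=O)c3ccccc3C2=O)c2c[nH]c3ccccc23)cc1Br`, gives 7320 nM. Compound 2, `O=C1C(O)=C(C(c2ccc([N+](=O)[O-])cc2)c2c(-c3ccccc3)[nH]c3ccccc23)C(=O)c2ccccc21`, gives 6770 nM, and compound 3, `O=C1C(O)=C(C(c2ccc([N+](=O)[O-])cc2)c2c[nH]c3ccc(Br)cc23)C(=O)c2ccccc21`, gives 14100 nM. On these numbers compound 1 sits with compound 2 on one side and compound 3 on the other, and both of its gaps stay within the usual scatter of repeated measurements, so the three compounds cannot be ranked against one another in this assay. Going by the values given here, no single-site step between measured compounds is available, and the aryl group on the saturated chain carbon is the only feature that varies in a way that can be followed here.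

Compound 4, `O=C1C(O)=C(C(c2ccc(F)cc2)c2c[nH]c3ccccc23)C(=O)c2ccccc21`, differs from compound 1 in one place: 4-fluorophenyl in place of 3-bromo-4-methoxyphenyl on a saturated chain carbon bound to an aromatic carbon and a double-bonded ring carbon. Among the compounds with values here, nothing among the measured compounds isolates the effect of this aryl group, so the expectation for compound 4 rests on the narrow band in which compound 1, compound 2 and compound 3 all lie. The step from compound 1 to compound 4 is expected to be a 1.1-fold higher number from compound 1 to compound 4 (0.04 log units; within the scatter), that is, no change beyond the scatter in either direction. Compound 4 is estimated at 8000 nM in this assay, within a range of 3500 nM to 18000 nM.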

Compound 4, half-maximal inhibitory concentration: 15800 nM
Beside the measured number, compound 4's estimate is 2.0-fold (0.30 log units) below it; measured number inside the range.
By their numbers in this assay, from the lowest: compounds 2, 1, 3 and 4 (each within the scatter of the next, the first and the last beyond it).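

In this assay, going by these compounds alone, 4-fluorophenyl in place of 3-bromo-4-methoxyphenyl on a saturated chain carbon bound to an aromatic carbon and a double-bonded ring carbon gives a 2.2-fold higher number from compound 1 to compound 4 (0.33 log units; beyond the scatter); this is the first single-site step and the first direct sign that the read-out responds to the aryl group at this position, though the step is modest and rests on one pair. The exchange replaces the bromine, the methoxy group and the fluorine-free ring pattern in one move, so this pair cannot assign the step to any one of these features. No measurement on hand explains the direction or size of the step.

The compounds shown leave open whether the bromine or the methoxy group accounts for the step, a question that 3-bromophenyl or 4-methoxyphenyl on the same carbon of the shared core would separate. They also leave open how the read-out responds to an aryl group carrying an amine or a carboxylic acid at this position.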